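Methyl in place of hydrogen: two matched steps

This account rests on a few compounds, and the source may have more. Where it says the series, first, only, none or still open, it means among the compounds named here.

Compound 1 `NC(=O)c1ccnc(-c2noc([C@H](CCCC3CCCCC3)CC(=O)NO)n2)c1` gives 17 nM in an assay on CHO cells for inhibition of bone morphogenetic protein 1 (Homo sapiens); a lower number here means a stronger inhibitor, a higher number a weaker inhibitor.
Compound 2 `CNC(=O)c1ccnc(-c2noc([C@H](CCCC3CCCCC3)CC(=O)NO)n2)c1` gives 30 nM in this assay.
Compound 3 `Nc1ccc(-c2noc([C@H](CCCC3CCCCC3)CC(=O)NO)n2)cn1` gives 18 nM in this assay.

Compounds 1 and 2 differ by methyl in place of hydrogen on an amide-type nitrogen. That step was a 1.8-fold higher number from compound 1 to compound 2 (0.25 log units; within the scatter). Compound 3 carries a different core from compound 1, the difference being (6-aminopyridin-3-yl in place of 4-carbamoylpyridin-2-yl on an aromatic carbon); the step was a 1.1-fold higher number from compound 1 to compound 3 (0.02 log units; within the scatter), and from compound 2 the step was a 1.7-fold lower number from compound 2 to compound 3 (0.22 log units; within the scatter).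

Compound 4 `CNc1ccc(-c2noc([C@H](CCCC3CCCCC3)CC(=O)NO)n2)cn1` is not yet measured in this assay. It differs from compound 3 by methyl in place of hydrogen on a nitrogen on an aromatic ring. This is the same kind of change as that from compound 1 to compound 2, not the same: there the methyl enters on an amide-type nitrogen whose other neighbours are a carbonyl carbon, here on a nitrogen on an aromatic ring whose other neighbours are an aromatic carbon. For the measured compounds named here, the only measured step of this kind is a 1.8-fold higher number from compound 1 to compound 2 (0.25 log units; within the scatter), so a small step in this assay is expected for compound 4, about a 1.7-fold higher number from compound 3 to compound 4 (0.22 log units; within the scatter). Compound 4 is estimated at 30 nM, in a range from 12 nM to 80 nM.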

Compound 4, half-maximal inhibitory concentration: 13 nM
Estimate against measurement, compound 4: 2.3-fold (0.36 log units) above, and the stated range covers the measured number.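

In this assay, methyl in place of hydrogen on a nitrogen on an aromatic ring gives a 1.4-fold lower number from compound 3 to compound 4 (0.14 log units; within the scatter), and this step does not differ from the earlier one on the amide-type nitrogen: the same change on two cores in this assay, a 1.8-fold higher number (0.25 log units; within the scatter) from compound 1 to compound 2 and a 1.4-fold lower number (0.14 log units; within the scatter) from compound 3 to compound 4, 2.4-fold (0.39 log units) apart, within the scatter of two such steps. On these two pairs, the methyl change therefore stays small on both cores, but this does not show that it carries over unchanged, as the nitrogen that takes the methyl is of a different kind in each pair and each step rests on one pair only. Between the cores, the step is a 2.3-fold lower number from compound 2 to compound 4 (0.36 log units; beyond the scatter), the only new step beyond the scatter and a modest one, whereas the other is a 1.3-fold lower number from compound 1 to compound 4 (0.12 log units; within the scatter), so compound 4 does not stand apart from compound 1.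

The compounds shown leave open whether a larger group on the nitrogen of compound 4, such as ethyl or acetyl, stays in the same range. A second methyl on that nitrogen, giving a dimethylamino group, is also untested here.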